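The source may hold more compounds than are shown below. What is called first, only, known or untested is meant among the compounds shown, and "the series" means these compounds.

Measured in an ADME assay on L02 cells (Homo sapiens) for cytotoxicity, read by MTT assay, with a stated time of 24 h; a higher number here means a weaker inhibitor, a lower number a stronger inhibitor:
- compound 1 `O=C1/C(=C/c2ccncc2)CN(S(=O)(=O)c2ccccc2)C/C1=C\c1ccccc1F`: 15900 nM
- compound 2 `O=C1/C(=C/c2ccncc2)CN(S(=O)(=O)c2ccc(F)cc2)C/C1=C\c1ccccc1F`: 15600 nM
- compound 3 `O=C1/C(=C/c2ccncc2)CN(S(=O)(=O)c2ccc(Br)cc2)C/C1=C\c1ccccc1F`: 19400 nM

Compound 1 stands within the scatter of both neighbours: a 1.0-fold lower number from compound 1 to compound 2 (0.01 log units; within the scatter) and a 1.2-fold higher number from compound 1 to compound 3 (0.09 log units; within the scatter). Compound 4 `O=C1/C(=C/c2ccncc2)CN(S(=O)(=O)c2ccccc2)C/C1=C\c1ccccc1C(F)(F)F` differs from compound 1 as follows: trifluoromethyl in place of fluoro on an aromatic carbon. This is trifluoromethyl in place of fluoro on an aromatic carbon, ortho to a large group. For the measured compounds named here, no measured step touches that place. The nearest in kind is a 1.2-fold higher number from compound 2 to compound 3 (0.09 log units; within the scatter), also bromo in place of fluoro on an aromatic carbon, though elsewhere on the molecule. All three steps are small, so nothing beyond the scatter is expected in this assay, and no direction can be argued. The expected change is a 1.1-fold lower number from compound 1 to compound 4 (0.03 log units; within the scatter). For compound 4 the estimate is 15000 nM, with an expected range from 8000 nM to 28000 nM.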

Compound 4, half-maximal inhibitory concentration: 12300 nM
The estimate for compound 4 lay 1.2-fold (0.09 log units) above the measured number; the range from low to high includes it.
By their numbers in this assay, from the lowest: compounds 4, 2, 1 and 3 (each within the scatter of the next).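

Replacing 2-fluorophenyl with 2-(trifluoromethyl)phenyl gives, in this assay, a 1.3-fold lower number from compound 1 to compound 4 (0.11 log units; within the scatter). For the compounds shown here, this is the first step at this place, as the earlier steps all lay elsewhere on the molecule, and it shows that four heavy atoms can replace one here without a shift beyond the scatter. No measurement given here bears on the reason for this step.

Going by these compounds, whether an amine or a carboxylic acid at this place would also stay within the scatter remains open. So does whether trifluoromethyl behaves the same alongside the fluoro and bromo groups of compounds 2 and 3.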